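Cyclopentyl for methyl on the amide of compound 1

The compounds below may be only part of what the source reports. "The series", "measured", "known", "first", "only" and "open" are said of these compounds alone.

Compound 1, `CCC1C(=O)N(C)c2cnc(-n3ccc4cc(C(=O)NC)ccc43)nc2N1c1ccn(C)n1`: 218 nM
Compound 2, `CCCCNS(=O)(=O)c1ccc(Nc2ncc3c(n2)N(C2CCCC2)[C@H](CC)C(=O)N3C)cc1`: 19.9 nM
Compound 3, `CC[C@@H]1C(=O)N(C)c2cnc(-n3ccc4cc(C(=O)NC)ccc43)nc2N1C1CCCC1`: 8.6 nM

Of the compounds shown here, three have been measured in an assay for inhibition of serine/threonine-protein kinase PLK2 (Homo sapiens), read by FRET and Z'-LYTE, with a stated time of 1 h; on this read-out higher numbers stand for weaker inhibition and lower numbers for stronger inhibition. Compound 1 stands at the highest of the three numbers, with 218 nM. The nearest is compound 2, which gives 19.9 nM, a gap beyond the scatter. The furthest is compound 3, which gives 8.6 nM, also beyond the scatter. Within the data shown here, no two of the measured compounds differ from each other in a single place, so no step is available from them.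

Compound 4, `CCC1C(=O)N(C)c2cnc(-n3ccc4cc(C(=O)NC5CCCC5)ccc43)nc2N1c1ccn(C)n1`, is to be measured in this assay. It differs from compound 1 by cyclopentyl in place of methyl on an amide-type nitrogen. Among the measured compounds shown here, no pair among the measured compounds carries this change, so its size and direction are not known from these data. On that basis the step is expected to be small, with no clear direction, and the estimate a 1.1-fold lower number from compound 1 to compound 4 (0.04 log units; within the scatter) is taken to lie within the scatter. Compound 4 is therefore expected to give about 200 nM in this assay, with a range from 70 nM to 600 nM.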

Compound 4, half-maximal inhibitory concentration: 90.9 nM
Compound 4: the middle estimate sits 2.2-fold (0.34 log units) above what was measured; the measured number falls inside the stated range.
By their numbers in this assay, from the lowest: compound 3; then compound 2; then compound 4; then compound 1.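

In this assay, among these compounds, the amide at this position proves open to change: replacing methyl with cyclopentyl on the amide-type nitrogen gives a 2.4-fold lower number from compound 1 to compound 4 (0.38 log units; beyond the scatter), a modest step that is the first single-place comparison in the set. It shows that this nitrogen accepts a substituent of five carbons carrying a non-aromatic ring, and that in this pair the number falls rather than rises as the group grows from one heavy atom to five. No other measurement shown bears on the reason for this step.

Among the compounds shown here, only this one pair carries the change, so it sets no pattern, and it remains open whether the same change would read the same way on compound 3, which carries the same methyl amide on a different substituted core. The compounds shown also do not tell whether the step belongs to cyclopentyl in particular, or how a cyclopropyl, a cyclohexyl, a longer chain or a ring bearing an amine would read on this nitrogen.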